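The source may hold more compounds than are shown below. What is called first, only, known or untested is meant among the compounds shown, and "the series" means these compounds.

Compound 1 `CCn1c(-c2cnc(C)nc2)nc2c(N[C@H]3CCN(C(=O)C4CCC4)C3)ncnc21` is measured in an ADME assay on LLC-PK1 cells (Sus scrofa) for permeability (a higher number here means that the compound crosses the layer faster, a lower number that the compound crosses the layer more slowly), and gives 32 10^-6 cm/s. Compound 2 `CCn1c(-c2ccc(C(F)(F)F)nc2)nc2c(O[C@H]3CCN(C(=O)N4CC(OC)C4)C3)ncnc21` gives 33 10^-6 cm/s in this assay, and compound 3 `CCn1c(-c2ccc(C(F)(F)F)nc2)nc2c(O[C@H]3CCN(C(=O)[C@H]4C[C@@H](OC)C4)C3)ncnc21` gives 35 10^-6 cm/s; the number for compound 1 lies within the scatter of both. Compound 4 `CCn1c(-c2cnc(C)nc2)nc2c(N[C@H]3CCN(C(=O)[C@H]4C[C@@H](OC)C4)C3)ncnc21` is the next compound to be measured. It differs from compound 1 in one place: methoxy in place of hydrogen on a saturated ring carbon. Among the measured compounds shown here, the only measured step that bears on a change of this kind is a 1.1-fold higher number from compound 2 to compound 3 (0.03 log units; within the scatter), where a methoxy-bearing four-membered ring replaced a different four-membered ring on the carbonyl and the number hardly moved. The expectation for compound 4 is therefore a step of no change at the digits printed from compound 1 to compound 4 (within the scatter), nothing beyond the scatter. Compound 4 is estimated at 32 10^-6 cm/s, between 20 10^-6 cm/s and 50 10^-6 cm/s.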

Compound 4, apparent permeability: 10 10^-6 cm/s
Estimate against measurement, compound 4: 3.2-fold (0.51 log units) above; measured number below the stated range.
By their numbers in this assay, from the lowest: compound 4; then compounds 1, 2 and 3 (each within the scatter of the next).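

In this assay, methoxy in place of hydrogen on this saturated ring carbon of the cyclobutyl group is not a silent change: it gives a 3.2-fold lower number from compound 1 to compound 4 (0.51 log units; beyond the scatter) as its step. The earlier step of a 1.1-fold higher number from compound 2 to compound 3 (0.03 log units; within the scatter) exchanged one methoxy-bearing four-membered ring for another, so it kept the methoxy and could not show what the methoxy itself does. Nothing measured here explains the fall.

On these data alone, whether a hydroxy or an amine on this ring carbon would give a similar step stays open. So does whether the step carries over to trifluoromethyl-bearing compounds such as compound 3.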